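This account rests on a few compounds, and the source may have more. Where it says the series, first, only, none or still open, it means among the compounds named here.

Measured so far:
Compound 1, `CC(c1c(F)cc2ncccc2c1F)n1cnc2ncc(-c3ccncc3)nc21`: 162 nM
Compound 2, `CC(c1c(F)cc2ncccc2c1F)n1cnc2ncc(-c3ccccc3)nc21`: 514 nM
Compound 3, `c1cnc2ccc(Cn3cnc4ncc(-c5ccncc5)nc43)cc2c1`: 1160 nM

In a functional assay on NCI-H1993 cells (Homo sapiens) for inhibition, read by CCK-8 assay, with a stated time of 72 h (on this read-out lower numbers stand for stronger inhibition and higher numbers for weaker inhibition), compound 1 gives 162 nM, and compound 2 gives 514 nM; the step between them, a 3.2-fold higher number from compound 1 to compound 2 (0.50 log units; beyond the scatter), rests on the change (phenyl in place of pyridin-4-yl on an aromatic carbon). Compound 3 gives 1160 nM, the highest number of the three; the difference between its core and that of compound 1 is not broken down here.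

Compound 4, `c1ccc(-c2cnc3ncn(Cc4ccc5ncccc5c4)c3n2)cc1`, is not yet measured. It differs from compound 3 by phenyl in place of pyridin-4-yl on an aromatic carbon, the same change already seen from compound 1 to compound 2. The estimate rests on that one earlier step, a 3.2-fold higher number from compound 1 to compound 2 (0.50 log units; beyond the scatter), taken on a different core, so the expected step from compound 3 to compound 4 is put at about a 3.0-fold higher number from compound 3 to compound 4 (0.48 log units; beyond the scatter). Compound 4 is therefore expected to give about 3500 nM, most likely between 1500 nM and 9000 nM.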

Compound 4, half-maximal inhibitory concentration: 7490 nM
Estimate against measurement, compound 4: 2.1-fold (0.33 log units) below; the range from low to high includes it.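

In this assay the change from pyridin-4-yl to phenyl runs the same way on the second core, giving a 6.5-fold higher number from compound 3 to compound 4 (0.81 log units; beyond the scatter). Set beside the earlier step, the two do not differ beyond what repeated measurements allow: the same change on two cores in this assay, a 3.2-fold higher number (0.50 log units; beyond the scatter) from compound 1 to compound 2 and a 6.5-fold higher number (0.81 log units; beyond the scatter) from compound 3 to compound 4, 2.0-fold (0.31 log units) apart, within the scatter of two such steps. So between these two cores the change carried over in direction and, as far as two steps can tell, in size, but two pairs set no rule for other cores and do not say why the number rises.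

The compounds shown leave open how other groups on that aromatic carbon would compare, such as an amine or a carboxylic acid. They also leave open whether a longer chain there would follow the same course on both cores.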